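Three Inactive Analogues and an Expected Fourth

The source may report more compounds than this note shows. Statements on the series, on what has been measured and on what is new or still open speak of the compounds shown alone.

Compound 1 `N#Cc1cn(COCc2ccccc2)c2ncnc(N)c12` is tested in a functional assay on KB cells (Homo sapiens) for cytotoxicity; a higher number here means a weaker inhibitor, a lower number a stronger inhibitor. In this assay compound 1 gives > 100000 nM, which is a limit of the assay and not a number. Compound 2 `CCOCn1cc(C#N)c2c(N)ncnc21` differs from it by methyl in place of phenyl on a saturated chain carbon bound to an oxygen on a saturated carbon. In this assay compound 2 gives > 100000 nM, again a limit. The step that the two limits leave unreadable from compound 1 to compound 2 cannot be read because of the limit of > 100000 nM in this assay, at which 3 of the 3 values shown sit. Compound 3 `NC(=O)c1cn(COCc2ccccc2)c2ncnc(N)c12` differs from compound 1 in its core by carbamoyl in place of cyano on an aromatic carbon. In this assay compound 3 gives > 100000 nM, also a limit, and the step that the two limits leave unreadable from compound 1 to compound 3 is likewise unreadable. Compound 4 `CCOCn1cc(C(N)=O)c2c(N)ncnc21` has not been measured. It differs from compound 3 by methyl in place of phenyl on a saturated chain carbon bound to an oxygen on a saturated carbon, the same change as that from compound 1 to compound 2, at the same place. Compound 4 is expected to sit at the limit as well, a step that the limit leaves unreadable from compound 3 to compound 4, resting on compound 3 giving > 100000 nM and on (the limit of > 100000 nM in this assay, at which 3 of the 3 values shown sit). Compound 4 is therefore estimated at 150000 nM, between 50000 nM and 600000 nM.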

Compound 4, half-maximal inhibitory concentration: > 100000 nM
Compound 4 was reported as a limit; the forecaster's own chance of this, stated with the estimate: 85%; the middle value lies beyond the limit too.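

Compound 4 is also reported as a limit, so neither new step, from compound 3 to compound 4 or from compound 2 to compound 4, can be read, because all the values sit at the same limit: the limit of > 100000 nM in this assay, at which 4 of the 4 values shown sit.

The compounds shown leave open how strong any of them is in this assay, and whether phenyl against methyl or cyano against carbamoyl makes any difference there.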